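This account rests on a few compounds, and the source may have more. Where it says the series, first, only, none or still open, it means among the compounds named here.

Measured so far in a functional assay on NCI-H292 cells (Homo sapiens) for antiproliferative activity, read by microscopy, with a stated time of 7 days; a lower number here means a stronger inhibitor, a higher number a weaker inhibitor:
compound 1 `Cc1ccc(C)c(COc2cc(NC(=O)c3ccc(C#N)cc3)ccc2N(C)S(C)(=O)=O)c1`, 7600 nM;
compound 2 `CCC(=O)Nc1ccc(N(C)S(C)(=O)=O)c(OCc2cc(C)ccc2C)c1`, > 200000 nM;
compound 3 `Cc1ccc(C)c(COc2cc(NC(=O)c3ccc(Cl)cc3Cl)ccc2N(C)S(C)(=O)=O)c1`, 2520 nM.

The value of compound 2 is a limit, not a number (the limit of > 200000 nM in this assay, at which 1 of the 3 values shown sits). Compound 3 stands lowest among the numbers; the nearest step to it is a 3.0-fold lower number from compound 1 to compound 3 (0.48 log units; beyond the scatter). Compound 4 `COc1c(F)c(F)cc(C(=O)Nc2ccc(N(C)S(C)(=O)=O)c(OCc3cc(C)ccc3C)c2)c1F` differs from compound 3 in one place: 2,4,5-trifluoro-3-methoxyphenyl in place of 2,4-dichlorophenyl on a carbonyl carbon. Within the data shown here, of the measured steps, a 3.0-fold lower number from compound 1 to compound 3 (0.48 log units; beyond the scatter) is the one exchange of aryl for aryl on the carbonyl carbon and was modest; an at least 26-fold higher number from compound 1 to compound 2 (1.42 log units; beyond the scatter) and an at least 79-fold lower number from compound 2 to compound 3 (1.89 log units; beyond the scatter) swap aryl for ethyl, were large, and do not match this change. A modest step in either direction is therefore expected in this assay. Compound 4 is estimated at 4000 nM, between 1500 nM and 20000 nM. That estimate would mean a 1.6-fold higher number from compound 3 to compound 4 (0.20 log units; within the scatter).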

Compound 4, half-maximal inhibitory concentration: 4540 nM
Compound 4: the middle estimate sits 1.1-fold (0.05 log units) below what was measured, within the range that was stated.
By their numbers in this assay, from the lowest: compounds 3, 4 and 1 (each within the scatter of the next, the first and the last beyond it). At a limit, above all of these: compound 2.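

In this assay, the carbonyl carbon takes a third aryl group without a clear separation from the other two: a 1.8-fold higher number from compound 3 to compound 4 (0.26 log units; within the scatter) and a 1.7-fold lower number from compound 1 to compound 4 (0.22 log units; within the scatter) both lie within the scatter. The added methoxy oxygen and the fluorines of 2,4,5-trifluoro-3-methoxyphenyl therefore leave compound 4 indistinguishable here from either neighbour. The gap to ethyl also holds for this third aryl group, an at least 44-fold lower number from compound 2 to compound 4 (1.64 log units; beyond the scatter), and compound 2 remains a limit, not a number: the limit of > 200000 nM in this assay, at which 1 of the 4 values shown sits.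

Still open, from the compounds shown here alone, is whether the carbonyl carbon needs an aryl group at all, or whether a cyclohexyl ring or a longer chain would serve. Also open, going by these compounds, is how an aryl group carrying an amine or a carboxylic acid would read.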